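A Fluoro Step on a Shared Core

A few compounds are considered here, and "the series" means these few. Any claim that something is new, unique, unknown or untested is made for them only; others in the source may bear on it.

In a functional assay on MCF7 cells (Homo sapiens) for cytotoxicity, read by MTT assay, with a stated time of 2 days, tested at 0.1 uM (on this read-out higher numbers stand for a weaker effect at the one concentration tested and lower numbers for a stronger effect), compound 2 `CC(=O)c1cc(/C=C/c2ccccc2)cc2cc(-c3ccccc3)[nH]c12` gives 99.5%. Compound 1 `CC(=O)c1cc(-c2ccccc2)cc2cc(-c3ccc(F)cc3)[nH]c12` gives 98.5% in this assay, and the gap between the two lies within the scatter, so they stand together near the weak end of the read-out. Compound 3 `CC(=O)c1cc(/C=C/c2ccccc2)cc2cc(-c3ccc(F)cc3)[nH]c12` differs from compound 2 in one place: fluoro in place of hydrogen on an aromatic carbon. For the measured compounds named here, no step between measured compounds is at hand to size this change. Because compound 1 gives 98.5% and compound 2 gives 99.5%, both near the weak end, compound 3 is expected to show a step of a number 1.5 percentage points lower from compound 2 to compound 3 (within the scatter) of no size beyond the scatter. Compound 3 is estimated at 98%, between 90% and 104%.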

Compound 3, a percentage reported as activity, at one concentration (the size of the read-out at that concentration, not a potency): 98.4%
Compound 3: middle estimate off by 0.4 percentage points, on the low side; measured number inside the range.
By their numbers in this assay, from the lowest: compounds 3, 1 and 2 (each within the scatter of the next).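

In this assay, for the compounds shown here, fluoro in place of hydrogen gives a number 1.1 percentage points lower from compound 2 to compound 3 (within the scatter), the first size for this change on this ring. With the fluoro present, 2-phenylethenyl in place of phenyl gives a number 0.1 percentage points lower from compound 1 to compound 3 (within the scatter), so neither place moves the read-out beyond the scatter at the one concentration tested. No measurement at hand offers an explanation for either step.

The compounds shown leave open whether an amine or a carboxylic acid in place of the fluoro would shift the read-out. They also leave open whether these compounds would separate at another concentration.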